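Volume of distribution across the series and the cyclopropyl amide

The source may report more compounds than this note shows. Statements on the series, on what has been measured and on what is new or still open speak of the compounds shown alone.

Three compounds of the series have been run in an ADME assay (Rattus norvegicus, strain Wistar Han) for pharmacokinetics; on this read-out lower numbers stand for narrower distribution and higher numbers for wider distribution into tissues. Compound 1 `CCC(=O)N1CC[C@H](Oc2ncnc3c2nc(-c2cnc(C)nc2)n3CC)C1` gives 2.4 L/kg. Compound 2 `CCn1c(-c2ccc(C(F)(F)F)nc2)nc2c(O[C@H]3CCN(C(=O)c4cocn4)C3)ncnc21` gives 2.6 L/kg. Compound 3 `CCn1c(-c2cnc(C)nc2)nc2c(N[C@H]3CCN(C(=O)N4CC(OC)C4)C3)ncnc21` gives 4.8 L/kg. Compound 2 stands among these with compound 1 as its nearest neighbour and compound 3 as its furthest, and both gaps lie within the scatter of the read-out, so the three numbers cannot be told apart. Among the measured compounds shown here, no pair of measured compounds differs in a single place, so no step has been measured.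

Compound 4 `CCn1c(-c2ccc(C(F)(F)F)nc2)nc2c(O[C@H]3CCN(C(=O)C4CC4)C3)ncnc21` is not yet measured. It differs from compound 2 in one place: cyclopropyl in place of 1,3-oxazol-4-yl on a carbonyl carbon. With no measured step to lean on, the expectation for compound 4 rests on the three numbers shown and on the change alone. The step from compound 2 to compound 4 in this assay is expected to be a 1.2-fold higher number from compound 2 to compound 4 (0.06 log units; within the scatter), that is, nothing beyond the scatter. Compound 4 is therefore estimated at 3 L/kg, with a range from 1.5 L/kg to 6 L/kg.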

Compound 4, volume of distribution: 8.3 L/kg
Compound 4: the middle estimate sits 2.8-fold (0.44 log units) below what was measured; the whole stated range lies below it.
By their numbers in this assay, from the lowest: compounds 1, 2, 3 and 4 (each within the scatter of the next, the first and the last beyond it).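

In this assay, among the compounds shown here, the acyl group is the first place with a measured step, and the step lies beyond the scatter: the number rises by a 3.2-fold higher number from compound 2 to compound 4 (0.50 log units; beyond the scatter) when cyclopropyl replaces 1,3-oxazol-4-yl on a carbonyl carbon. The change therefore exchanges a five-membered aromatic ring with 2 hetero atoms for a three-membered non-aromatic ring of carbon only, and the read-out responds to that exchange at this position. Nothing available bears on why the number rises.

Open, from the compounds shown here alone, is whether the step belongs to cyclopropyl itself or to the loss of 1,3-oxazol-4-yl, a question that a tert-butyl group or a phenyl ring on the same carbonyl carbon would address. Also open, going by these compounds, is whether the same change gives a similar step on the cores of compound 1 and compound 3.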